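The compounds below may be only part of what the source reports. "The series", "measured", "known", "first", "only" and "open" are said of these compounds alone.

Going by the values given here, compound 2 `O=C(O)CCc1ccc(NC(=O)c2nnc(Cc3cccc(F)c3)s2)cc1` is the weaker of the two compounds measured so far in a functional assay on CHO cells for agonist activity at Free fatty acid receptor 1 (Homo sapiens), read by FLIPR and calcium flux, tested at 1 uM; on this read-out lower numbers stand for an effect already at smaller amounts and higher numbers for an effect only at larger amounts of compound. In this assay, among the compounds with values here, compound 2 gives 5020 nM, while its nearest neighbour, compound 1 `Cc1ccc(OCc2nnc(C(=O)Nc3ccc(CCC(=O)O)cc3)s2)cc1C`, gives 1130 nM; the one known step, a 4.4-fold higher number from compound 1 to compound 2 (0.65 log units; beyond the scatter), arose from placing 3-fluorophenyl in place of 3,4-dimethylphenoxy on a saturated chain carbon bound to an aromatic carbon. Compound 3 `O=C(O)CCc1ccc(NC(=O)c2nnc(Cc3ccc(Cl)cc3)s2)cc1` is not yet measured; its change from compound 2 is 4-chlorophenyl in place of 3-fluorophenyl on a saturated chain carbon bound to an aromatic carbon. That earlier step is the only one that bears on this move, and it concerned a far larger exchange of the group at the same place; the swap of one halogenated phenyl for another is smaller, so no step beyond the scatter is firmly expected in this assay, with a slight lean toward a lower number. Compound 3 is therefore estimated at 3500 nM, within 1200 nM to 10000 nM, which means an expected step of a 1.4-fold lower number from compound 2 to compound 3 (0.16 log units; within the scatter).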

Compound 3, half-maximal effective concentration: 2390 nM
Estimate against measurement, compound 3: 1.5-fold (0.17 log units) above; the range from low to high includes it.
By their numbers in this assay, from the lowest: compound 1; then compound 3; then compound 2.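

In this assay, replacing 3-fluorophenyl with 4-chlorophenyl gives a 2.1-fold lower number from compound 2 to compound 3 (0.32 log units; beyond the scatter), which shows that even an exchange of one halogenated phenyl for another can shift the number at this place, on a saturated chain carbon bound to an aromatic carbon. The 4-chlorophenyl group closes part of the distance to 3,4-dimethylphenoxy but not all of it, since a 2.1-fold higher number from compound 1 to compound 3 (0.33 log units; beyond the scatter), leaving the 3,4-dimethylphenoxy compound with the lowest number of the three. No available evidence explains these differences.

On these data alone, what 3-chlorophenyl or 4-fluorophenyl would give at this place remains open, so the kind of halogen cannot be told apart from its place on the phenyl. Also open, as far as these compounds go, is the contribution of the ether oxygen in 3,4-dimethylphenoxy, which a 3,4-dimethylphenyl group at the same place would address.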